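Swapping the isobutyl arm of compound 1 for a pyrazole

The compounds below may be only part of what the source reports. "The series", "measured", "known", "first", "only" and "open" are said of these compounds alone.

Of the compounds shown here, three sharing one core have been measured in an assay on HEK293 cells for agonist activity at transient receptor potential cation channel subfamily M member 8 (Homo sapiens), read by fluorescence and calcium flux, with a stated time of 15 min; a higher number here means that more compound is needed for the effect, a lower number that less compound is needed. Compound 1 `Cc1ccc(OCC(=O)N(Cc2cccs2)CC(C)C)cc1` gives 900 nM, the second highest of the three numbers. Compound 2 `CCN(Cc1cncs1)C(=O)COc1ccc(C)cc1` gives 1100 nM, within the scatter of compound 1. Compound 3 `CCN(Cc1ccco1)C(=O)COc1ccc(C)cc1` gives 489 nM, also within the scatter of compound 1. Among the measured compounds shown here, the one step that leaves the scatter is a 2.2-fold lower number from compound 2 to compound 3 (0.35 log units; beyond the scatter), and it concerns the heteroaryl group on the saturated chain carbon.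

Compound 4 `Cc1ccc(OCC(=O)N(Cc2cccs2)c2ccn[nH]2)cc1` has not yet been measured. It differs from compound 1 in one place: 1H-pyrazol-5-yl in place of isobutyl on an amide-type nitrogen. For the measured compounds named here, no measured step touches this position, since the only step beyond the scatter alters a different part of the molecule, so there is nothing in the measured compounds to show which way this change pulls. The expectation is therefore a step near the scatter, a 1.3-fold higher number from compound 1 to compound 4 (0.12 log units; within the scatter), with wide uncertainty. Compound 4 is estimated at 1200 nM, somewhere between 300 nM and 5000 nM.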

Compound 4, half-maximal effective concentration: 0.2 nM
Compound 4: middle estimate off by 6000-fold (3.78 log units), on the high side, and the stated range ends above it.
By their numbers in this assay, from the lowest: compound 4; then compounds 3, 1 and 2 (each within the scatter of the next, the first and the last beyond it).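

In this assay, among the compounds shown here, the group on the amide-type nitrogen proves far more influential than the earlier compounds could show: 1H-pyrazol-5-yl in place of isobutyl gives a 4500-fold lower number from compound 1 to compound 4 (3.65 log units; beyond the scatter), whereas the only earlier step beyond the scatter, a heteroaryl change elsewhere in the molecule, was a 2.2-fold lower number from compound 2 to compound 3 (0.35 log units; beyond the scatter). This single change removes a chain with no ring, hydrogen-bond donor or acceptor and introduces a five-membered aromatic ring with 1 hydrogen-bond donor and 1 hydrogen-bond acceptor. No available measurement bears on why the number falls so far.

The compounds shown leave open whether the step goes with the aromatic ring itself or with the hydrogen on the pyrazole nitrogen, a question that a phenyl ring or a 1-methylpyrazol-5-yl group at this nitrogen could address. They also leave open whether the step would persist with furan-2-yl on the saturated chain carbon.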